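Chain length at the quaternary carbon of the iminosugar core

This account rests on a few compounds, and the source may have more. Where it says the series, first, only, none or still open, it means among the compounds named here.

Measured so far:
compound 1 `CCCCC[C@]1(CO)NC[C@H](O)[C@@H](O)[C@@H]1O`: 19 nM
compound 2 `CC[C@]1(CO)NC[C@H](O)[C@@H](O)[C@@H]1O`: 6000 nM

In an assay on isolated protein for inhibition of lysosomal alpha-glucosidase (Homo sapiens), read by fluorescence, with stated times of 45 min and 30 min (on this read-out higher numbers stand for weaker inhibition and lower numbers for stronger inhibition), compound 2 gives the highest of the two numbers; its nearest neighbour is compound 1, and the step of a 320-fold higher number from compound 1 to compound 2 (2.50 log units; beyond the scatter) shows how far apart they sit. Compound 3 `CCCCCC[C@]1(CO)NC[C@H](O)[C@@H](O)[C@@H]1O` is not yet measured. It differs from compound 2 by butyl in place of hydrogen on a saturated chain carbon, two bonds along the chain from a saturated ring carbon, running one carbon beyond the chain of compound 1. Within the data shown here, the only relevant step is the loss of propyl from compound 1 to compound 2, which cost a great deal; restoring and extending the chain is therefore expected to reverse that cost. The estimated step is a 600-fold lower number from compound 2 to compound 3 (2.78 log units; beyond the scatter), and compound 3 is expected near 10 nM (range 3 nM to 40 nM).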

Compound 3, inhibition constant: 6.1 nM
Estimate against measurement, compound 3: 1.6-fold (0.21 log units) above; low and high end bracket the measured number.
By their numbers in this assay, from the lowest: compound 3; then compound 1; then compound 2.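

In this assay this position still responds to chain length beyond compound 1: methyl in place of hydrogen, five bonds along the chain from a saturated ring carbon, gives a 3.1-fold lower number from compound 1 to compound 3 (0.49 log units; beyond the scatter) and so adds a modest gain to the much larger step a 980-fold lower number from compound 2 to compound 3 (2.99 log units; beyond the scatter). Across the three compounds the number falls as the chain lengthens, and none goes against this. Nothing available explains this trend. Still open, on these data alone, is whether a longer chain continues this fall or ends it, and whether a chain carrying a phenyl ring or an amine follows the same trend.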